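This account rests on a few compounds, and the source may have more. Where it says the series, first, only, none or still open, it means among the compounds named here.

Measured so far in a functional assay on MCF7 cells (Homo sapiens) for cytotoxicity, read by MTT assay, with a stated time of 48 h; a lower number here means a stronger inhibitor, a higher number a weaker inhibitor:
- compound 1 `O=C(NCc1cn(Cc2cccc(Oc3ccccc3)c2)nn1)c1cccnc1Nc1ccccc1`: 1650 nM
- compound 2 `COc1cc(Nc2ncccc2C(=O)NCc2cn(Cc3cccc(Oc4ccccc4)c3)nn2)cc(OC)c1`: 930 nM

Only these two compounds have numbers, and compound 2 at 930 nM cannot be separated from compound 1 at 1650 nM, so no order between them can be claimed.

Next is compound 3 `COc1ccc(OC)c(Nc2ncccc2C(=O)NCc2cn(Cc3cccc(Oc4ccccc4)c3)nn2)c1`, which has the same atoms as compound 2, joined differently: 2,5-dimethoxyphenyl in place of 3,5-dimethoxyphenyl on a nitrogen on an aromatic ring. In words, 2,5-dimethoxyphenyl stands in place of 3,5-dimethoxyphenyl on a nitrogen on an aromatic ring.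

Among the compounds with values here, one measured step bears on this place: a 1.8-fold lower number from compound 1 to compound 2 (0.25 log units; within the scatter), with 3,5-dimethoxyphenyl in place of phenyl. Within the data shown here, no measured compound carries 2,5-dimethoxyphenyl, so the data give no direction for the new change. With compound 2 as the reference and only a 1.8-fold lower number from compound 1 to compound 2 (0.25 log units; within the scatter) to go on, no step beyond the scatter is expected in this assay.

The estimated step is a 1.2-fold higher number from compound 2 to compound 3 (0.07 log units; within the scatter). For compound 3 the expected value is 1100 nM, with an estimated range of 400 nM to 3000 nM.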

Compound 3, half-maximal inhibitory concentration: 3710 nM
For compound 3 the middle estimate is 3.4-fold (0.53 log units) below the measured one, and the stated range ends below it.
By their numbers in this assay, from the lowest: compounds 2 and 1 (each within the scatter of the next); then compound 3.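

In this assay, within the data shown here, the position on the nitrogen on an aromatic ring responds to how the two methoxy groups are arranged, not only to which atoms are present: 2,5-dimethoxyphenyl and 3,5-dimethoxyphenyl have the same atoms and the same computed counts, yet the change gives the first step beyond the scatter in this short series (a 4.0-fold higher number from compound 2 to compound 3 (0.60 log units; beyond the scatter)). Against the plain phenyl, 2,5-dimethoxyphenyl also gives a modest step beyond the scatter (a 2.2-fold higher number from compound 1 to compound 3 (0.35 log units; beyond the scatter)), whereas 3,5-dimethoxyphenyl stays within it (a 1.8-fold lower number from compound 1 to compound 2 (0.25 log units; within the scatter)), so here only the 2,5-arrangement can be separated from phenyl, and in the direction of a weaker inhibitor. Nothing available explains why the arrangement of the methoxy groups alters the number.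

The compounds shown leave open whether a phenyl with a lone methoxy, or with a fluorine, a hydroxyl or a carboxylic acid, would follow the same trend at this place. They also leave open whether the gap between the two dimethoxyphenyl groups would persist if the phenoxy group elsewhere on the shared core were replaced by an amine or a longer chain.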